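The compounds below may be only part of what the source reports. "The series", "measured", "known", "first", "only" and "open" are said of these compounds alone.

For the measured compounds named here, in a functional assay on MCF7 cells (Homo sapiens) for antiproliferative activity, read by MTT assay, with a stated time of 72 h (on this read-out higher numbers stand for weaker inhibition and lower numbers for stronger inhibition), compound 2 `O=C(Nc1ccc(Nc2nccc(Nc3ccccc3Cl)n2)cc1)Nc1ccc(Cl)c(C(F)(F)F)c1` gives 27900 nM, the higher of the two numbers so far, and compound 1 `O=C(Nc1ccc(Nc2nccc(NC3CCCC3)n2)cc1)Nc1ccc(Cl)c(C(F)(F)F)c1` gives 2330 nM. Going by the values given here, the only measured step, a 12-fold higher number from compound 1 to compound 2 (1.08 log units; beyond the scatter), is large and comes from 2-chlorophenyl in place of cyclopentyl on the same nitrogen. Compound 3 `Cn1cc(Nc2ccnc(Nc3ccc(NC(=O)Nc4ccc(Cl)c(C(F)(F)F)c4)cc3)n2)cn1` changes that place again: 1-methyl-1H-pyrazol-4-yl in place of 2-chlorophenyl on a nitrogen on an aromatic ring. Among the compounds with values here, with this one step as the sole guide, a sizeable move to a lower number is expected in this assay, partway back towards compound 1 at 2330 nM. The expected size of the change is a 4.7-fold lower number from compound 2 to compound 3 (0.67 log units; beyond the scatter). The estimate for compound 3 is 6000 nM, with an expected range of 1500 nM to 25000 nM.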

Compound 3, half-maximal inhibitory concentration: 9770 nM
Compound 3: the middle estimate sits 1.6-fold (0.21 log units) below what was measured; the range from low to high includes it.
By their numbers in this assay, from the lowest: compound 1; then compound 3; then compound 2.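

At this nitrogen, 1-methyl-1H-pyrazol-4-yl in place of 2-chlorophenyl gives a 2.9-fold lower number from compound 2 to compound 3 (0.46 log units; beyond the scatter), yet in place of cyclopentyl it gives a 4.2-fold higher number from compound 1 to compound 3 (0.62 log units; beyond the scatter). The position therefore distinguishes between the two aromatic rings, while cyclopentyl still gives the lowest number of the three groups. Nothing available gives a reason for this order. From the compounds shown here alone, it remains open whether cyclopropyl or cyclohexyl on this nitrogen would give a number lower than that of compound 1. An unsubstituted phenyl would show how much of the high number of compound 2 goes with its chlorine.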